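Swapping one methoxy for acetoxy on compound 2

The source may hold more compounds than are shown below. What is called first, only, known or untested is meant among the compounds shown, and "the series" means these compounds.

- compound 1 `COc1cc(C2OC(c3ccc(N)c(C)c3)=NN2C(C)=O)cc(OC)c1OC`: 0.042 uM
- compound 2 `COc1cc(C2OC(c3ccc(N(C)C)cc3)=NN2C(C)=O)cc(OC)c1OC`: 0.033 uM
- compound 3 `COc1cc(C2OC(c3cccc(N(C)C)c3)=NN2C(C)=O)cc(OC)c1OC`: 0.16 uM

These values come from a functional assay on HCT-15 cells (Homo sapiens); on this read-out lower numbers stand for an effect already at smaller amounts and higher numbers for an effect only at larger amounts of compound. Compound 2 stands at the low end of these numbers. Its nearest neighbour is close, with a step of a 1.3-fold lower number from compound 1 to compound 2 (0.10 log units; within the scatter). The remaining neighbour lies further off, with a step of a 4.8-fold higher number from compound 2 to compound 3 (0.69 log units; beyond the scatter).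

Compound 4 `COc1cc(C2OC(c3ccc(N(C)C)cc3)=NN2C(C)=O)cc(OC)c1OC(C)=O` has not yet been measured. It differs from compound 2 in one place: acetyl in place of methyl on an oxygen on an aromatic ring. Put simply, one methoxy of compound 2 becomes acetoxy in compound 4.

For the measured compounds named here, no measured step touches that place. All three swap the substituted phenyl group on a carbon with a double bond to nitrogen, so they offer only a sense of scale. The largest is a 4.8-fold higher number from compound 2 to compound 3 (0.69 log units; beyond the scatter), and a similar one is a 3.8-fold higher number from compound 1 to compound 3 (0.58 log units; beyond the scatter). The data therefore fix no direction for the new change. A modest rise in this assay is a cautious judgement, and a result within the scatter would be no surprise. The estimated change is a 2.4-fold higher number from compound 2 to compound 4 (0.38 log units; beyond the scatter). For compound 4 the expected value is 0.08 uM, with an estimated range from 0.02 uM to 0.3 uM.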

Compound 4, concentration for half-maximal effect: 78 uM
Compound 4: middle estimate off by 980-fold (2.99 log units), on the low side; the whole stated range lies below it.
By their numbers in this assay, from the lowest: compounds 2 and 1 (each within the scatter of the next); then compound 3; then compound 4.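

In this assay, for the compounds shown here, the methoxy to acetoxy swap gives a 2400-fold higher number from compound 2 to compound 4 (3.37 log units; beyond the scatter) and so far exceeds every step among the earlier compounds, the largest of which is a 4.8-fold higher number from compound 2 to compound 3 (0.69 log units; beyond the scatter) in a series that varied only the substituted phenyl group. The earlier compounds shown here all carried the same methoxy groups and could say nothing about this place, whereas this single pair shows that the group on this oxygen can matter much more than the phenyl changes did, even though only methyl gives way to acetyl. No measurement shown here explains why the number rises so steeply.

On these data alone, it remains open whether the jump belongs to acetyl in particular or would follow other replacements of the methyl, and a free hydroxyl, an ethyl ether or a longer acyl chain such as propionyl on the same oxygen would help to tell these apart. As far as these compounds go, it also remains open whether the same swap would have a similar effect on compound 1 or compound 3, which carry different phenyl groups.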